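Chain extension on the core of compound 1

The compounds below may be only part of what the source reports. "The series", "measured", "known", "first", "only" and "open" are said of these compounds alone.

Compound 1 `CCCn1c(=O)[nH]c2c(cnn2-c2cccc(Cl)c2)c1=N` stands highest of the three measured compounds. In an assay on membranes from brain for binding affinity to adenosine receptor A1 (Rattus norvegicus), read by radioligand binding, tested at 20 uM (a higher number here means more inhibition at the concentration tested (going by the name of the read-out), a lower number less inhibition), compound 1 gives 68%. Compound 2 `Cn1c(=O)[nH]c2c(cnn2-c2ccc(N)cc2)c1=N` carries a methyl instead of the propyl and a different aryl group; in this assay compound 2 gives 0%, a gap beyond the scatter. Compound 3 `CCCn1ncc2c(=N)n(C)c(=O)[nH]c21` lacks the aryl group; in this assay compound 3 gives 5%, also beyond the scatter below compound 1.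

Compound 4 `CCCCn1c(=O)[nH]c2c(cnn2-c2cccc(Cl)c2)c1=N` is not yet measured. It differs from compound 1 by methyl in place of hydrogen on a saturated chain carbon, three bonds along the chain from an aromatic nitrogen, read one bond further out as propyl to butyl. Among the compounds with values here, no measured pair shows this change alone, so no step size is known; a single added chain carbon is expected to move the read-out within the scatter, with no direction favoured. Compound 4 is expected at 65%, within 40% to 85%. That estimate corresponds to an expected step of a number 3 percentage points lower from compound 1 to compound 4 (within the scatter).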

Compound 4, a percentage reported as inhibition, at one concentration (the size of the read-out at that concentration, not a potency): 58%
Compound 4: the middle estimate sits 7 percentage points above what was measured; the range from low to high includes it.
By their numbers in this assay, from the lowest: compounds 2 and 3 (each within the scatter of the next); then compounds 4 and 1 (each within the scatter of the next).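

Propyl to butyl on the chain of compound 1 is the first single change in the series that can be read in this assay (a number 10 percentage points lower from compound 1 to compound 4 (within the scatter)). At this position, one added chain carbon therefore leaves the two compounds indistinguishable, so the read-out does not depend sharply on chain length between propyl and butyl. No measured evidence bears on why.

Still open, on these data alone, is whether a longer chain such as pentyl, or a branched chain such as isobutyl, would hold the read-out at this level. Shorter ethyl and methyl chains on the same core also remain open.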